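The source may hold more compounds than are shown below. What is called first, only, known or untested is meant among the compounds shown, and "the series" means these compounds.

Measured compounds, read in a functional assay on NCI-H1975 cells (Homo sapiens) for inhibition, read by MTT assay, with a stated time of 72 h; on this read-out lower numbers stand for stronger inhibition and higher numbers for weaker inhibition:
compound 1 `O=C(CSc1nc(Nc2ccccc2)c2ccccc2n1)Nc1cccc(Cl)c1`: 8460 nM
compound 2 `O=C(CSc1nc(Nc2ccccc2)c2ccccc2n1)Nc1cccc(Br)c1`: 10100 nM
compound 3 `CCc1cccc(NC(=O)CSc2nc(Nc3ccccc3)c3ccccc3n2)c1`: 12000 nM

The three differ only in the group on the amide-type nitrogen, each carrying a substituted phenyl there. Compound 3 carries the 3-ethylphenyl; its number sits beside those of compounds 1 and 2, as the steps of a 1.4-fold higher number from compound 1 to compound 3 (0.15 log units; within the scatter) and a 1.2-fold higher number from compound 2 to compound 3 (0.07 log units; within the scatter) both fall within the scatter. Nothing among the three sets one apart.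

Compound 4 `O=C(CSc1nc(Nc2ccccc2)c2ccccc2n1)Nc1ccc(Cl)cc1` is not yet measured. Against compound 3 the change is 4-chlorophenyl in place of 3-ethylphenyl on an amide-type nitrogen. Going by the values given here, the measured steps bear on it only partly: they exchange chloro, bromo and ethyl on the ring while keeping the same attachment pattern, and none moves the substituent to another position, so the shift to a 4-chlorophenyl has no direct precedent here. Since every exchange on this ring so far stayed within the scatter, the expectation for this assay is a step of a 1.2-fold lower number from compound 3 to compound 4 (0.08 log units; within the scatter), that is, no step beyond the scatter in either direction.

Compound 4 is therefore estimated at 10000 nM, with a range from 4000 nM to 25000 nM in this assay.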

Compound 4, half-maximal inhibitory concentration: 8040 nM
The estimate for compound 4 lay 1.2-fold (0.09 log units) above the measured number; measured number inside the range.
By their numbers in this assay, from the lowest: compounds 4, 1, 2 and 3 (each within the scatter of the next).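

In this assay, going by these compounds alone, the 4-chlorophenyl on the amide-type nitrogen is the first change that alters the attachment pattern rather than only exchanging the substituent, and it stays within the scatter (a 1.1-fold lower number from compound 1 to compound 4 (0.02 log units; within the scatter)). The exchanges against the other two rings read the same way (a 1.3-fold lower number from compound 2 to compound 4 (0.10 log units; within the scatter)) and (a 1.5-fold lower number from compound 3 to compound 4 (0.17 log units; within the scatter)), so all four substituted phenyl groups now sit within the scatter of one another. Across these compounds, neither the identity of the substituent nor the change from the 3-substituted rings to the 4-chlorophenyl separates one number from another, and no measurement offered here speaks to why the values lie so close together.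

As far as these compounds go, it stays open whether an unsubstituted phenyl, or a carboxylic acid, an amine or a longer chain such as hexyl in place of the ring on the amide-type nitrogen, would give a step beyond the scatter. All four compounds keep the rest of the molecule unchanged, so nothing here shows how a change elsewhere on the shared core would read in this assay.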